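A few compounds are considered here, and "the series" means these few. Any claim that something is new, unique, unknown or untested is made for them only; others in the source may bear on it.

In an ADME assay on RD cells (Homo sapiens) for cytotoxicity, read by MTT assay, with a stated time of 24 h (a lower number here means that less compound is tolerated, a higher number that more compound is tolerated), compound 1 `CC(CCOc1ccc(-c2noc(C(F)(F)F)n2)cc1)CCN1CCN(c2ccnc(N)c2)C1=O` gives 48100 nM. Compound 2 `CC(CCOc1ccc(/C=N/O)cc1)CCN1CCN(c2ccnc(N)c2)C1=O` gives > 100000 nM in this assay, which is a limit of the measurement and not a number. Going by the values given here, the one measured step, an at least 2.0-fold higher number from compound 1 to compound 2 (0.31 log units; beyond the scatter), therefore has no exact size; it is known only to end at the limit described by the limit of > 100000 nM in this assay, at which 1 of the 2 values shown sits, where one of the two measured values sits.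

Compound 3 `CCONCc1ccc(OCCC(C)CCN2CCN(c3ccnc(N)c3)C2=O)cc1` differs from compound 2 in one place: a group of 5 heavy atoms (3 carbon, 1 nitrogen, 1 oxygen; no ring) in place of a group of 3 heavy atoms (1 carbon, 1 nitrogen, 1 oxygen; no ring), on an aromatic carbon. Among the compounds with values here, this exchange is far smaller than the one that separates compound 1 from compound 2, where a five-membered aromatic ring bearing a trifluoromethyl group gave way to a short chain. Within the data shown here, no measured step covers an exchange of two such short chains; the only step in hand, an at least 2.0-fold higher number from compound 1 to compound 2 (0.31 log units; beyond the scatter), says merely that the chain-bearing compound is tolerated up to the limit of the measurement. Compound 3 is expected to behave much like compound 2, so the estimated step of an at least 1.2-fold lower number from compound 2 to compound 3 (0.09 log units; that floor lies within the scatter) is no change beyond the scatter. In this assay compound 3 is therefore expected to give about 80000 nM, within a range from 25000 nM to 100000 nM, and quite possibly only the limit again.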

Compound 3, half-maximal cytotoxic concentration: 7370 nM
Compound 3: the middle estimate sits 11-fold (1.04 log units) above what was measured; the whole stated range lies above it.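

At this position, on an aromatic carbon para to a large group, swapping one short ringless group for another is not a neutral exchange, even though the two groups differ little in size and have the same counts of hydrogen-bond donors and acceptors: in this assay there is an at least 13-fold lower number from compound 2 to compound 3 (1.13 log units; beyond the scatter), a large step. The earlier comparison had favoured the ringless group over 5-(trifluoromethyl)-1,2,4-oxadiazol-3-yl, but compound 3 goes against that pattern, with a 6.5-fold lower number from compound 1 to compound 3 (0.81 log units; beyond the scatter), so having no ring does not by itself go with a higher number here. As far as these compounds go, the true size of the first step remains unknown, since the value for compound 2 is a limit of the assay and not a number: the limit of > 100000 nM in this assay, at which 1 of the 3 values shown sits.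

The compounds shown do not separate the parts of the change, namely the ethyl group on the oxygen and the loss of the double bond found in the group of compound 2. A plain aminomethyl or a methoxyaminomethyl group at this position would help tell these apart, and nothing shown explains why the number falls.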